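The source may report more compounds than this note shows. Statements on the series, on what has been measured and on what is new or still open speak of the compounds shown alone.

Measured so far in an ADME assay on HEK293 cells (Homo sapiens) for cytotoxicity, read by resazurin assay, with a stated time of 48 h; on this read-out higher numbers stand for lower toxicity in this test and lower numbers for higher toxicity in this test:
Compound 1, `O=S(=O)(Nc1ccc2oc(-c3ccccc3)nc2c1)c1ccccc1C(F)(F)F`, gives 80000 nM.
Compound 2, `Cc1cccc(S(=O)(=O)Nc2ccc(-c3nc4ccccc4o3)cc2)c1`, reaches only the assay limit of > 100000 nM.
Compound 3, `O=S(=O)(Nc1ccc2oc(-c3ccccc3)nc2c1)c1ccccc1Cl`, gives 73000 nM.

Compound 3 and compound 1 sit within the scatter of each other, the step of a 1.1-fold lower number from compound 1 to compound 3 (0.04 log units; within the scatter) being the only measured step among these three; the limit of > 100000 nM in this assay, at which 1 of the 3 values shown sits, marks the limit reached by compound 2. The next compound, compound 4, `C=Cc1ccc(S(=O)(=O)Nc2ccc3oc(-c4ccccc4)nc3c2)cc1`, changes the same ring: 4-vinylphenyl in place of 2-chlorophenyl on a sulfonyl sulfur. Going by the values given here, the single measured step on this ring, a 1.1-fold lower number from compound 1 to compound 3 (0.04 log units; within the scatter), was within the scatter, so no movement beyond the scatter is expected in this assay for the step of a 1.1-fold higher number from compound 3 to compound 4 (0.04 log units; within the scatter). Compound 4 is therefore expected to give about 80000 nM, most likely between 40000 nM and 160000 nM, though a value reported only as a limit would not be surprising.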

Compound 4, half-maximal cytotoxic concentration: 53000 nM
The estimate for compound 4 lay 1.5-fold (0.18 log units) above the measured number, within the range that was stated.
By their numbers in this assay, from the lowest: compounds 4, 3 and 1 (each within the scatter of the next). At a limit, above all of these: compound 2.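

Here, 4-vinylphenyl in place of 2-chlorophenyl on the sulfonyl sulfur gives a 1.4-fold lower number from compound 3 to compound 4 (0.14 log units; within the scatter) in this assay, with the sulfonamide and the rest of the molecule unchanged. This place therefore takes a group with no halogen and a double bond outside aromatic rings, and the number stays within the scatter. Nothing given here bears on the reason for this small step. As far as these compounds go, whether a group carrying an amine or a carboxylic acid at this place would move the number beyond the scatter stays open.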